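Working notes: dimethylamino in place of hydroxy

A few compounds are considered here, and "the series" means these few. Any claim that something is new, unique, unknown or untested is made for them only; others in the source may bear on it.

Measured in a functional assay on NCI-H226 cells (Homo sapiens) for inhibition; a lower number here means a stronger inhibitor of growth, a higher number a weaker inhibitor of growth:
- compound 1 `NS(=O)(=O)c1ccc(/C=C/c2ccc(O)c(O)c2)cc1`: 14000 nM
- compound 2 `NS(=O)(=O)c1ccc(/C=C/c2ccc(F)cc2)cc1`: 7970 nM
- compound 3 `NS(=O)(=O)c1ccc(/C=C/c2ccc(O)cc2)cc1`: 11100 nM

Compound 3, at 11100 nM, lies within the scatter of both other compounds, so the three values give no ranking.

The next compound is compound 4 `CN(C)c1ccc(/C=C/c2ccc(S(N)(=O)=O)cc2)cc1`, with dimethylamino in place of hydroxy on an aromatic carbon, para to a large group (dimethylamino in place of hydroxy on an aromatic carbon).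

Within the data shown here, two measured steps bear on this change. One is a 1.4-fold higher number from compound 2 to compound 3 (0.14 log units; within the scatter), with hydroxy in place of fluoro on an aromatic carbon. The other is a 1.3-fold lower number from compound 1 to compound 3 (0.10 log units; within the scatter), with hydrogen in place of hydroxy on an aromatic carbon. Both are small, and neither exceeds the scatter. Among the measured compounds shown here, no measured compound carries dimethylamino, so these steps are only an indirect guide and the range has to stay wide.

In this assay, no step beyond the scatter is expected, though a modest move towards stronger growth inhibition remains possible. The estimated step is a 1.6-fold lower number from compound 3 to compound 4 (0.20 log units; within the scatter). For compound 4 the expected value is 7000 nM, with an estimated range from 2000 nM to 20000 nM.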

Compound 4, concentration for 50% growth inhibition: 12100 nM
Beside the measured number, compound 4's estimate is 1.7-fold (0.24 log units) below it; the measured number falls inside the stated range.
By their numbers in this assay, from the lowest: compounds 2, 3, 4 and 1 (each within the scatter of the next).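

Among these compounds, at this position, on an aromatic carbon para to a large group, this assay gives a first reading for a group larger than hydroxy or fluoro: dimethylamino in place of hydroxy gives (a 1.1-fold higher number from compound 3 to compound 4 (0.04 log units; within the scatter)), and dimethylamino in place of fluoro gives (a 1.5-fold higher number from compound 2 to compound 4 (0.18 log units; within the scatter)). The earlier compounds shown here carried only small groups here, so the new point is that going from 1 heavy atom to 3, and from 1 hydrogen-bond donor to 0, still leaves the read-out within the scatter, and the four compounds still give no ranking. No accompanying data explain this flat response.

As far as these compounds go, it remains open whether any group at this position can move the number beyond the scatter, and a carboxylic acid, a primary amine or a longer alkoxy chain here would test that. From the compounds shown here alone, whether changes elsewhere on the shared core would have more effect than changes at this position also remains open.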